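A few compounds are considered here, and "the series" means these few. Any claim that something is new, unique, unknown or untested is made for them only; others in the source may bear on it.

Measured in a physicochemical assay for solubility, in phosphate buffer, with a stated time of 18 h; a lower number here means a less soluble compound, a higher number a more soluble compound:
- compound 1 `CCCCc1nc(C(C)(C)C)nc2nc(N)c(C#N)c(N)c12`: 6000 nM
- compound 2 `CC(C)(C)c1nc(-c2ccsc2)c2c(N)c(C#N)c(N)nc2n1`: 40000 nM
- compound 3 `CC(C)(C)c1nc(-c2ccn[nH]2)c2c(N)c(C#N)c(N)nc2n1`: 13500 nM

Compound 3 holds the middle place of these three numbers. Compound 1 is its nearest neighbour, a 2.3-fold higher number from compound 1 to compound 3 (0.35 log units; beyond the scatter), and compound 2 is further off, a 3.0-fold lower number from compound 2 to compound 3 (0.47 log units; beyond the scatter).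

The next compound, compound 4 `CC(C)(C)c1nc(-c2ncco2)c2c(N)c(C#N)c(N)nc2n1`, carries 1,3-oxazol-2-yl in place of 1H-pyrazol-5-yl on an aromatic carbon, with the rest of the structure unchanged: 1,3-oxazol-2-yl in place of 1H-pyrazol-5-yl on an aromatic carbon.

Within the data shown here, three measured steps bear on this change, all of them at this same carbon. Besides the two above there is a 6.7-fold higher number from compound 1 to compound 2 (0.82 log units; beyond the scatter). All three are modest, and the closest guide is the swap of one ring for another in compound 2, a 3.0-fold lower number from compound 2 to compound 3 (0.47 log units; beyond the scatter). Among the measured compounds shown here, no compound measured so far carries 1,3-oxazol-2-yl, so the direction is poorly defined, with only a slight lean upward and nothing expected beyond the scatter. The expected step is a 1.3-fold higher number from compound 3 to compound 4 (0.12 log units; within the scatter). For compound 4 the estimated value is 18000 nM, with an expected range from 6000 nM to 50000 nM.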

Compound 4, solubility: 50000 nM
Compound 4: the middle estimate sits 2.8-fold (0.44 log units) below what was measured; low and high end bracket the measured number.
By their numbers in this assay, from the lowest: compound 1; then compound 3; then compounds 2 and 4 (each within the scatter of the next).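

In this assay, the two five-membered aromatic rings at this carbon do not behave alike, even though each has 2 hetero atoms and the same heavy-atom count: 1,3-oxazol-2-yl, which has no hydrogen-bond donor, in place of 1H-pyrazol-5-yl, which has one, gives a clear change (a 3.7-fold higher number from compound 3 to compound 4 (0.57 log units; beyond the scatter)). The oxazole cannot be told apart from thiophen-3-yl (a 1.3-fold higher number from compound 2 to compound 4 (0.10 log units; within the scatter)), so compound 3 now sits apart from both of these ring-bearing compounds. All three rings stand beyond the scatter from butyl, including the oxazole (an 8.3-fold higher number from compound 1 to compound 4 (0.92 log units; beyond the scatter)).

As far as these compounds go, whether the missing donor matters stays open, since a 1-methyl-1H-pyrazol-5-yl group at this carbon would be needed to separate it from the change of ring, and an amine or a carboxylic acid there is also untested in these compounds. Nothing available here accounts for the difference between the two rings.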